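A few compounds are considered here, and "the series" means these few. Any claim that something is new, unique, unknown or untested is made for them only; others in the source may bear on it.

Solubility across the series has been read in a physicochemical assay for solubility, read by HPLC, in simulated intestinal fluid, with a stated time of 16 h, tested at 125 ug/mL; on this read-out lower numbers stand for lower solubility and higher numbers for higher solubility. Compound 1 `CNC(=O)c1cc(C(=O)NC2CC2)cn(Cc2ccc(OC)cc2)c1=O` gives 263 ug/mL. Compound 2 `CNC(=O)c1cc(C(=O)NC2CC2)cn(Cc2cccc(C)c2)c1=O` gives 88 ug/mL, and compound 3 `CNC(=O)c1cc(C(=O)NC2CC2)cn(Cc2ccccc2F)c1=O` gives 88 ug/mL. The step of a 3.0-fold lower number from compound 1 to compound 2 (0.48 log units; beyond the scatter) and the step of a 3.0-fold lower number from compound 1 to compound 3 (0.48 log units; beyond the scatter) are both modest and beyond the scatter, whereas no change at the digits printed from compound 2 to compound 3 (within the scatter). Compound 3 therefore stands level with compound 2 at the digits shown, the two together being the lowest of the three numbers, with compound 1 furthest from it.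

Compound 4 `CNC(=O)c1cc(C(=O)NC2CC2)cn(Cc2cccc3c2CCN3)c1=O` is the next member to be read in this assay. Its change from compound 3 is 2,3-dihydro-1H-indol-4-yl in place of 2-fluorophenyl on a saturated chain carbon bound to an aromatic nitrogen. Among the measured compounds shown here, no measured step covers an entering group of this kind: the three measured steps all exchange one six-membered aromatic ring of carbon only for another, and the one that carries a hydrogen-bond donor and acceptor into this position has no precedent here. The measured steps show that changes at this position have moved the number modestly at most, so a step of similar size is expected, with the direction uncertain.

Compound 4 is accordingly expected to give 180 ug/mL, with a range from 70 ug/mL to 450 ug/mL. That estimate means an expected step of a 2.0-fold higher number from compound 3 to compound 4 (0.31 log units; beyond the scatter).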

Compound 4, solubility: 100 ug/mL
Estimate against measurement, compound 4: 1.8-fold (0.26 log units) above; the range from low to high includes it.
By their numbers in this assay, from the lowest: compounds 2, 3 and 4 (each within the scatter of the next); then compound 1.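

In this assay the entering 2,3-dihydro-1H-indol-4-yl gives a 1.1-fold higher number from compound 3 to compound 4 (0.06 log units; within the scatter) and, set against 3-methylphenyl, a 1.1-fold higher number from compound 2 to compound 4 (0.06 log units; within the scatter), so compound 2, compound 3 and compound 4 read as one level. Among the compounds shown here, this position on a saturated chain carbon bound to an aromatic nitrogen therefore takes a group with a five-membered non-aromatic ring, a hydrogen-bond donor and a hydrogen-bond acceptor without leaving that level, which the earlier compounds, all with a single six-membered aromatic ring of carbon only, could not show. Against 4-methoxyphenyl the same group gives a 2.6-fold lower number from compound 1 to compound 4 (0.42 log units; beyond the scatter), leaving compound 1 as the only member apart from the other three, and no supporting data bear on why the numbers fall this way.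

Still open, from the compounds shown here alone, is whether a carboxylic acid or an open-chain amine at this position would stay at the level of compound 4 or move beyond it. Also open, going by these compounds, is whether 4-hydroxyphenyl or 4-ethoxyphenyl in place of 4-methoxyphenyl would stay near compound 1 at 263 ug/mL or fall to the level of the other three.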